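This account rests on a few compounds, and the source may have more. Where it says the series, first, only, none or still open, it means among the compounds named here.

Working notes on the series.

Among the measured compounds shown here, compound 3 `COc1ccc(-c2ccc(OCc3cc(C(=O)NS(=O)(=O)c4ccc(CN)cc4)oc3C)cc2)cc1` stands highest among the three numbers so far: in an assay on cells for displacement of a labelled ligand from prostaglandin E2 receptor EP4 subtype (Homo sapiens), read by scintillation counting (a higher number here means a weaker inhibitor, a lower number a stronger inhibitor), compound 3 gives 100 nM. The two companions sit close together below it. For the measured compounds named here, compound 1 `COc1ccc(-c2ccc(OCc3cc(C(=O)NS(=O)(=O)c4ccccc4)oc3C)cc2)c(C)c1` gives 21 nM in this assay, and compound 2 `Cc1oc(C(=O)NS(=O)(=O)c2ccccc2)cc1COc1ccc(-c2ccccc2)cc1` gives 25 nM; the one measured step, a 1.2-fold higher number from compound 1 to compound 2 (0.08 log units; within the scatter), lies at the biaryl end and does not touch the sulfonyl side.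

Compound 4 `COc1ccc(-c2ccc(OCc3cc(C(=O)NS(=O)(=O)Cc4ccccc4)oc3C)cc2)cc1` differs from compound 3 at the sulfonyl sulfur: benzyl in place of 4-(aminomethyl)phenyl on a sulfonyl sulfur. Going by the values given here, no measured step bears directly on this position. What the values show is that the two compounds carrying an unsubstituted phenylsulfonyl, compound 1 and compound 2, sit beyond the scatter below compound 3, which carries the aminomethyl group. Removing that group in compound 4 is therefore expected to move the number back towards those two, with the extra methylene an unknown; the step of a 2.5-fold lower number from compound 3 to compound 4 (0.40 log units; beyond the scatter) is estimated as a decrease beyond the scatter. For compound 4 in this assay the estimate is 40 nM, with a range from 12 nM to 130 nM.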

Compound 4, inhibition constant: 3 nM
For compound 4 the middle estimate is 13-fold (1.12 log units) above the measured one; the whole stated range lies above it.
By their numbers in this assay, from the lowest: compound 4; then compounds 1 and 2 (each within the scatter of the next); then compound 3.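

In this assay, among the compounds shown here, the group on the sulfonyl sulfur turns out to be a strong lever: a 33-fold lower number from compound 3 to compound 4 (1.52 log units; beyond the scatter) comes with benzyl in place of 4-(aminomethyl)phenyl, whereas the only earlier measured step lay at the biaryl end and did not touch this position. The change alters two things at once, removing the aminomethyl group and setting a methylene between the ring and the sulfonyl sulfur, and this single step does not separate the two. No measured evidence on hand explains the size of the drop.

Open, from the compounds shown here alone, is whether the step belongs mainly to the loss of the aminomethyl group or to the methylene. Also open, going by these compounds, is how the number responds to a longer chain on the sulfonyl sulfur, such as 2-phenylethyl, or to an amine or a carboxylic acid on the benzyl ring.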